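Trading a 4-methylphenyl for a vinyl at the core

The source may hold more compounds than are shown below. What is called first, only, known or untested is meant among the compounds shown, and "the series" means these compounds.

The compounds share one core, an amide-bearing bicyclic scaffold, and differ only at a single aromatic carbon. In a functional assay on KYSE-70 cells for antiproliferative activity against KYSE-70 cell line (Homo sapiens), read by MTT assay, with a stated time of 72 h (on this read-out higher numbers stand for weaker inhibition and lower numbers for stronger inhibition), compound 2 `O=C(Nc1cccc(F)c1)c1cc(=O)[nH]c2cc(-c3ccsc3)ccc12` gives 5100 nM. Compound 3 `Cc1ccc(-c2ccc3c(C(=O)Nc4cccc(F)c4)cc(=O)[nH]c3c2)cc1` reaches only the limit of this assay, > 20000 nM. Compound 1 `O=C(Nc1ccc(C(F)(F)F)cc1)c1cc(=O)[nH]c2cc(Br)ccc12` likewise stops at the limit, > 20000 nM. The one step measured is an at least 3.9-fold higher number from compound 2 to compound 3 (0.59 log units; beyond the scatter), so compound 3 sits at the weak end of what is shown, beside compound 1 at the limit of > 20000 nM in this assay, at which 2 of the 3 values shown sit.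

Compound 4 `C=Cc1ccc2c(C(=O)Nc3cccc(F)c3)cc(=O)[nH]c2c1` differs from compound 3 by vinyl in place of 4-methylphenyl on an aromatic carbon. Going by the values given here, no measured step swaps a 4-methylphenyl for a vinyl, so the only guidance is that a small bromine in compound 1 and the 4-methylphenyl in compound 3 both end at the limit, while the thiophen-3-yl of compound 2 gives a measurable number. A small vinyl is therefore expected to leave the value near the limit, with an at least 1.1-fold lower number from compound 3 to compound 4 (0.04 log units; that floor lies within the scatter) as the estimated step. Compound 4 is expected to give about 18000 nM, within a range of 5000 nM to 60000 nM.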

Compound 4, half-maximal inhibitory concentration: 9700 nM
Compound 4: the middle estimate sits 1.9-fold (0.27 log units) above what was measured; measured number inside the range.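

At this aromatic carbon, a much smaller group with no ring returns a measurable number in this assay: vinyl in place of 4-methylphenyl gives an at least 2.0-fold lower number from compound 3 to compound 4 (0.31 log units; beyond the scatter). Vinyl also cannot be told apart from thiophen-3-yl, which does carry a ring, because a 1.9-fold higher number from compound 2 to compound 4 (0.28 log units; within the scatter) stays within the usual scatter, so a ring here is not needed for this level of activity. On these data alone, the true size of the gain over 4-methylphenyl remains unknown because compound 3 gives only a limit, not a number: the limit of > 20000 nM in this assay, at which 2 of the 4 values shown sit.

As far as these compounds go, it remains open whether an amine, a carboxylic acid or a longer chain on this carbon would give a stronger or weaker result. It is also unclear whether an unsubstituted phenyl would behave like thiophen-3-yl or like 4-methylphenyl.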